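Methylating the amide nitrogen of compound 1

This account rests on a few compounds, and the source may have more. Where it says the series, first, only, none or still open, it means among the compounds named here.

Measured so far in an assay on Jurkat cells for inhibition of nuclear factor NF-kappa-B p105 subunit (Homo sapiens); on this read-out lower numbers stand for stronger inhibition and higher numbers for weaker inhibition:
compound 1 `O=C(Nc1cc(Cl)cc(Cl)c1)c1cnc(Cl)nc1C(F)(F)F` — 500 nM
compound 2 `O=C(Nc1cc(Cl)cc(Cl)c1)c1cnc(N2CCCCC2)nc1C(F)(F)F` — 5000 nM
compound 3 `O=C(Nc1cc(Cl)cc(Cl)c1)c1cncnc1C(F)(F)F` — > 10000 nM, which is a limit of the assay rather than a number

Compound 1 stands lowest of the two numbers obtained; the change from compound 1 to compound 2 gave a 10-fold higher number from compound 1 to compound 2 (1.00 log units; beyond the scatter). Compound 3 reached only the limit (the limit of > 10000 nM in this assay, at which 1 of the 3 values shown sits), so the change from compound 1 to compound 3 is read as an at least 20-fold higher number from compound 1 to compound 3 (1.30 log units; beyond the scatter) and that from compound 2 to compound 3 as an at least 2.0-fold higher number from compound 2 to compound 3 (0.30 log units; that floor lies within the scatter).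

Compound 4 `CN(C(=O)c1cnc(Cl)nc1C(F)(F)F)c1cc(Cl)cc(Cl)c1` differs from compound 1 by methyl in place of hydrogen on an amide-type nitrogen. Both measured steps concern the substituent on the aromatic carbon of the core, not the amide nitrogen, so none bears directly on this change. A modest rise is expected, a 4.0-fold higher number from compound 1 to compound 4 (0.60 log units; beyond the scatter), giving for compound 4 an estimate of 2000 nM within 300 nM to 10000 nM.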

Compound 4, half-maximal inhibitory concentration: 2300 nM
Estimate against measurement, compound 4: 1.2-fold (0.06 log units) below; the measured number falls inside the stated range.
By their numbers in this assay, from the lowest: compound 1; then compound 4; then compound 2. At a limit, above all of these: compound 3.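

Among the compounds shown here, the amide nitrogen is the first position outside the substituent on the core's aromatic carbon to be probed, and it responds to a single methyl: in this assay, methyl in place of hydrogen gives a 4.6-fold higher number from compound 1 to compound 4 (0.66 log units; beyond the scatter). The amide hydrogen is therefore not essential, since compound 4 still gives a number and not an assay limit. Nothing shown accounts for this step.

On these data alone, whether ethyl, a longer chain or an amine-bearing chain on this nitrogen would raise the number further remains open. Also open, as far as these compounds go, is whether methyl has a similar effect when piperidin-1-yl replaces chloro on the core.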